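Side-chain swap from compound 2 to compound 4

This account rests on a few compounds, and the source may have more. Where it says the series, first, only, none or still open, it means among the compounds named here.

Working notes on the series. In an ADME assay on liver for metabolic stability, with Liver microsome (Homo sapiens) as the target, read by LC-MS, using microsomes (a higher number here means faster removal of the compound, a lower number slower removal), compound 1 `O=C(NCc1cc(Cl)ccc1-n1cnnn1)[C@@H]1[C@H]2C[C@H]2CN1C(=O)[C@H](O)CC1CC1` gives < 14 mL.min-1.g-1, which is a limit of the assay rather than a number (the limit of < 14 mL.min-1.g-1 in this assay, at which 1 of the 3 values shown sits). Compound 3 `CC(C)(C)C[C@@H](O)C(=O)N1CC[C@@H]2C[C@@]21C(=O)NCc1cc(Cl)ccc1-n1cnnn1` gives 27 mL.min-1.g-1 in this assay. Compound 2 `COC(C)(C)[C@@H](O)C(=O)N1N=CC[C@H]1C(=O)NCc1cc(Cl)ccc1-n1cnnn1` is the starting point here. In this assay compound 2 gives < 12 mL.min-1.g-1, again a limit of the assay and not a number (the limit of < 12 mL.min-1.g-1 in this assay, at which 1 of the 3 values shown sits). Compound 2 thus stands with compound 1 among the two entries reported only as limits. Compound 4 `CC(C)(C)C[C@@H](O)C(=O)N1N=CC[C@H]1C(=O)NCc1cc(Cl)ccc1-n1cnnn1` differs from compound 2 in one place: neopentyl in place of 1-methoxy-1-methylethyl on a saturated chain carbon bound to a carbonyl carbon and an oxygen on a saturated carbon. No measured step of this kind is shown. Compound 3 carries the same neopentyl group on a different core and shows 27 mL.min-1.g-1. For compound 4 a small rise is expected, of a size an at least 1.5-fold higher number from compound 2 to compound 4 (0.17 log units; that floor lies within the scatter) that may still sit within the usual scatter. Compound 4 is estimated at 18 mL.min-1.g-1, with a range from 8 mL.min-1.g-1 to 40 mL.min-1.g-1.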

Compound 4, intrinsic clearance in microsomes: 22 mL.min-1.g-1
Estimate against measurement, compound 4: 1.2-fold (0.09 log units) below; the measured number falls inside the stated range.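

Neopentyl in place of 1-methoxy-1-methylethyl on a saturated chain carbon bound to a carbonyl carbon and an oxygen on a saturated carbon gives, in this assay, an at least 1.8-fold higher number from compound 2 to compound 4 (0.26 log units; that floor lies within the scatter). Among the compounds shown here, this is the first single-place reading of this position, and it shows no change beyond the scatter, though the true step may be larger. Compound 2 is a limit of the assay and not a number, so the step has only a floor: the limit of < 12 mL.min-1.g-1 in this assay, at which 1 of the 4 values shown sits.

The compounds shown leave open how an amine, a carboxylic acid or a longer chain would read at this place. As far as these compounds go, whether the same swap reads alike on the core of compound 1 also stays open.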